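The source may report more compounds than this note shows. Statements on the series, on what has been measured and on what is new or still open speak of the compounds shown alone.

Of the compounds shown here, three have been measured in a functional assay on LoVo cells (Homo sapiens) for inhibition, read by MTT assay, with a stated time of 48 h; on this read-out higher numbers stand for weaker inhibition and lower numbers for stronger inhibition. Compound 1 `COc1ccc(N(C)c2nc(C)nc3ccccc23)cc1OCCN` gives 421 nM, which is the second highest of the three numbers. Compound 2 `COc1ccc(N(C)c2nc(C)nc3ccccc23)cc1C(=O)NCC[Se]C#N` gives 561 nM, and the step of a 1.3-fold higher number from compound 1 to compound 2 (0.12 log units; within the scatter) lies within the scatter. Among the measured compounds shown here, compound 3 `Cc1nc(N(C)c2ccc([Se]C#N)c(F)c2)c2ccccc2n1`, which carries the selenocyanate directly on the aryl ring rather than on a side chain, gives 13 nM; its number lies well below that of compound 1, beyond the scatter, but no single-site step connects the two.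

Compound 4 `COc1ccc(N(C)c2nc(C)nc3ccccc23)cc1C(=O)OCC[Se]C#N` has not yet been measured in this assay. It differs from compound 1 by a group of 8 heavy atoms (4 carbon, 1 nitrogen, 2 oxygen, 1 selenium; no ring) in place of a group of 4 heavy atoms (2 carbon, 1 nitrogen, 1 oxygen; no ring), on an aromatic carbon. For the measured compounds named here, the one measured step that bears on this change is a 1.3-fold higher number from compound 1 to compound 2 (0.12 log units; within the scatter), where a closely related chain bearing a selenocyanate enters at the same place and the number hardly moves. Compound 4 is therefore expected to give about 500 nM, with a range from 200 nM to 1300 nM. The expected step of a 1.2-fold higher number from compound 1 to compound 4 (0.07 log units; within the scatter) is estimated to stay within the scatter.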

Compound 4, half-maximal inhibitory concentration: 2960 nM
For compound 4 the middle estimate is 5.9-fold (0.77 log units) below the measured one; the whole stated range lies below it.
By their numbers in this assay, from the lowest: compound 3; then compounds 1 and 2 (each within the scatter of the next); then compound 4.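

Set on the same aromatic carbon, the two selenocyanate chains are not interchangeable in this assay: changing the amide link to an ester gives a 5.3-fold higher number from compound 2 to compound 4 (0.72 log units; beyond the scatter), beyond the scatter, although the chains differ only in the atom on the carbonyl carbon. Replacing the 2-aminoethoxy group with the ester chain gives a 7.0-fold higher number from compound 1 to compound 4 (0.85 log units; beyond the scatter), also beyond the scatter, whereas the amide chain had left the number within the scatter, so the selenocyanate end alone does not set the number at this position. No measurement shown here offers an explanation for this difference.

Still open, going by these compounds, is whether the gap follows the ester link itself or would persist with a longer chain between the carbonyl and the selenocyanate. The compounds shown also leave open how an ester chain ending in an amine, a carboxylic acid or a plain nitrile would compare.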